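Two arylthiomethyl indoles measured, a third awaiting its number

This account rests on a few compounds, and the source may have more. Where it says the series, first, only, none or still open, it means among the compounds named here.

Compound 1 `CCOC(=O)c1c(CSc2ccc(OC)cc2)n(C)c2ccc(O)cc12`: 3100 nM
Compound 2 `CCOC(=O)c1c(CSc2ccccc2C(F)(F)F)n(C)c2ccc(O)cc12`: 1200 nM

Of the compounds shown here, two sharing the same core have been measured in an assay on cells for inhibition of Polyunsaturated fatty acid 5-lipoxygenase (Homo sapiens), read by HPLC, with a stated time of 15 min; on this read-out higher numbers stand for weaker inhibition and lower numbers for stronger inhibition. In this assay compound 1 gives 3100 nM, the higher of the two numbers, and compound 2 gives 1200 nM, a gap that lies beyond the usual scatter. Going by the values given here, no single-point step between these two is recorded, so only their two values speak.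

Compound 3 `CCOC(=O)c1c(CSc2cc(C)cc(C)c2)n(C)c2ccc(O)cc12` has not yet been measured. It differs from compound 1 by 3,5-dimethylphenyl in place of 4-methoxyphenyl on a sulfur. Among the compounds with values here, nothing among the measured pair reports on this particular change, so the expectation rests on compound 1 alone. The step from compound 1 to compound 3 is expected to be a 1.4-fold lower number from compound 1 to compound 3 (0.15 log units; within the scatter), small and most likely within the scatter, with the direction uncertain. Compound 3 is therefore estimated at 2200 nM, with a range from 700 nM to 7000 nM.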

Compound 3, half-maximal inhibitory concentration: 2700 nM
Beside the measured number, compound 3's estimate is 1.2-fold (0.09 log units) below it; low and high end bracket the measured number.
By their numbers in this assay, from the lowest: compound 2; then compounds 3 and 1 (each within the scatter of the next).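

In this assay, placing 3,5-dimethylphenyl instead of 4-methoxyphenyl on the sulfur gives a 1.1-fold lower number from compound 1 to compound 3 (0.06 log units; within the scatter) and leaves the two compounds indistinguishable. Going by these compounds alone, this is the first reading on this position from a single change, and it shows that the oxygen and the hydrogen-bond acceptor leaving with 4-methoxyphenyl can be exchanged for an all-carbon aromatic ring of the same heavy-atom count without a change beyond the scatter. Nothing measured independently explains this outcome. Still open, going by these compounds, is how the number would respond if the aromatic ring on the sulfur carried an amine or a carboxylic acid. On these data alone, it is equally open whether a saturated chain could take the place of that ring on the sulfur.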